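Thioether tail variation on the shared core

A few compounds are considered here, and "the series" means these few. Any claim that something is new, unique, unknown or untested is made for them only; others in the source may bear on it.

Measured so far:
- compound 1 `C[C@@H]1CCN(c2cc(-c3ccccc3)nc3ncnn23)C[C@@H]1N(C)c1ncnc2[nH]ccc12` — in a functional assay on HGC-27 cells (Homo sapiens) for inhibition, read by MTT assay, with a stated time of 72 h (on this read-out lower numbers stand for stronger inhibition and higher numbers for weaker inhibition), compound 1 reaches only the assay limit > 100000 nM.
- compound 2 `Cc1cc(N2CC[C@@H](C)[C@@H](N(C)c3ncnc4[nH]ccc34)C2)n2nc(SCc3ccc(F)cc3)nc2n1` — in this assay compound 2 gives 26000 nM.
- compound 3 `Cc1cc(N2CC[C@@H](C)[C@@H](N(C)c3ncnc4[nH]ccc34)C2)n2nc(SCC3CCCCC3)nc2n1` — in this assay compound 3 gives 11500 nM.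

Compound 3 holds the lowest of the two numbers; compound 1 sits at the limit (the limit of > 100000 nM in this assay, at which 1 of the 3 values shown sits). Going by the values given here, the one step in hand is a 2.3-fold lower number from compound 2 to compound 3 (0.35 log units; beyond the scatter), a modest gain on the saturated chain carbon bound to a sulfur. Compound 4 `Cc1cc(N2CC[C@@H](C)[C@@H](N(C)c3ncnc4[nH]ccc34)C2)n2nc(SCCCc3ccccc3)nc2n1` differs from compound 3 by phenethyl in place of cyclohexyl on a saturated chain carbon bound to a sulfur. Among the compounds with values here, no measured step covers a phenethyl tail, so the expectation rests on the comparable size of the step from compound 2 to compound 3; compound 4 is expected to land near compound 3, with a 1.2-fold lower number from compound 3 to compound 4 (0.06 log units; within the scatter). The estimate for compound 4 in this assay is 10000 nM, expected between 4000 nM and 30000 nM.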

Compound 4, half-maximal inhibitory concentration: > 100000 nM
Compound 4 was reported as a limit (the forecaster's own chance of this, stated with the estimate: 10%); at least 10-fold (1.00 log units) between middle value and limit.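

Changing the tail alone can remove measurable inhibition in this assay: the change to phenethyl gives an at least 8.6-fold higher number from compound 3 to compound 4 (0.93 log units; beyond the scatter), and against the 4-fluorophenyl tail it gives an at least 3.8-fold higher number from compound 2 to compound 4 (0.58 log units; beyond the scatter). Compound 4 stands at a limit of the assay, > 100000 nM. An aromatic ring alone does not separate the tails, as compound 2 also carries one and gives 26000 nM. The limit now recurs in the series: the limit of > 100000 nM in this assay, at which 2 of the 4 values shown sit.

Going by these compounds, whether the chain length or the phenyl ring of the 3-phenylpropyl tail matters remains open, and a 3-cyclohexylpropyl tail would separate the two. Also open, on these data alone, is whether an amine or a carboxylic acid on the tail gives a measurable number.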